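A shorter tether on compound 1, measured against hexokinase-2

This account rests on a few compounds, and the source may have more. Where it says the series, first, only, none or still open, it means among the compounds named here.

Measured so far:
compound 1 `O=C(CI)NCCCCCC(=O)NCCCCCCNc1ncnc2c1ncn2[C@@H]1O[C@H](COP(=O)(O)OP(=O)(O)OP(=O)(O)O)[C@@H](O)[C@H]1O` — 0%
compound 2 `CN(CCCCN(C)C(=O)CCCNc1ncnc2c1ncn2[C@@H]1O[C@H](COP(=O)(O)OP(=O)(O)OP(=O)(O)O)[C@@H](O)[C@H]1O)C(=O)CCCNC(=O)CI` — 0%
compound 3 `CN(CCCCN(C)C(=O)CCCCNc1ncnc2c1ncn2[C@@H]1O[C@H](COP(=O)(O)OP(=O)(O)OP(=O)(O)O)[C@@H](O)[C@H]1O)C(=O)CCCCNC(=O)CI` — 0%

In an assay on isolated protein for inhibition of hexokinase-2 (Rattus norvegicus), with a stated time of 6 h, tested at 10 mM (on this read-out higher numbers stand for more inhibition at the one concentration tested (going by the name of the read-out) and lower numbers for less inhibition), compound 1 gives 0%. Compound 2 gives 0% and compound 3 gives 0%, so compound 1 stands level with both at the digits reported, the nearest being compound 2 and the furthest compound 3, each within the scatter. Among the compounds with values here, no pair of measured compounds differs in only one place, so no measured step is available to set the size of a change.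

Compound 4 `O=C(I)NCC(=O)NCCCCCCNc1ncnc2c1ncn2[C@@H]1O[C@H](COP(=O)(O)OP(=O)(O)OP(=O)(O)O)[C@@H](O)[C@H]1O` differs from compound 1 in one place: a group of 4 heavy atoms (1 carbon, 1 nitrogen, 1 oxygen, 1 iodine; no ring) in place of a group of 9 heavy atoms (6 carbon, 1 nitrogen, 1 oxygen, 1 iodine; no ring), on a saturated chain carbon bound to a carbonyl carbon. Since all three measured compounds sit at one level in this assay and none of them separates from the others beyond the scatter, the step is expected to be none beyond the scatter: no change at the digits printed from compound 1 to compound 4 (within the scatter). Compound 4 is therefore estimated at 0%, with a range from -8% to 10%.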

Compound 4, a percentage reported as inhibition, at one concentration (the size of the read-out at that concentration, not a potency): 0%
Compound 4: middle estimate and measured number agree at the digits printed; low and high end bracket the measured number.
By their numbers in this assay, from the lowest: compounds 1, 2, 3 and 4 (each within the scatter of the next).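

In this assay, within the data shown here, the exchange of the 4-(((iodomethyl)carbonyl)amino)butyl group for the smaller group, on a saturated chain carbon bound to a carbonyl carbon, gives no change at the digits printed from compound 1 to compound 4 (within the scatter) and provides the first step that can be read at a single place. At this position, then, going from 9 heavy atoms to 4 while the group still carries its iodine and carbonyl leaves the read-out at the level shared by the other compounds. No measurement at hand accounts for this outcome.

With every compound at that one level, the step cannot show whether this position matters for inhibition of the enzyme at all. On these data alone, whether an amine or a carboxylic acid on this carbon would lift the read-out from that level remains open.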